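Closing the open diol side chain into a ring

The source may report more compounds than this note shows. Statements on the series, on what has been measured and on what is new or still open speak of the compounds shown alone.

compound 1 `O=C1c2c[n+]([O-])c3ccccc3c2C(=O)c2c1c1ccccc1n2Cc1cn([C@@H]2C[C@H](O)[C@@H](CO)O2)nn1` gives 150 nM
compound 2 `O=C1c2c[n+]([O-])c3ccccc3c2C(=O)c2c1c1ccccc1n2Cc1cn(C[C@H](O)CO)nn1` gives > 1000 nM
compound 3 `O=C1c2c[n+]([O-])c3ccccc3c2C(=O)c2c1c1ccccc1n2Cc1cn(CC(O)CO)nn1` gives > 1000 nM

These results come from a functional assay on SH-SY5Y cells (Homo sapiens) for cytotoxicity, read by MTT assay, with a stated time of 72 h (a higher number here means a weaker inhibitor, a lower number a stronger inhibitor), and share one core. The value of compound 3, > 1000 nM, is a limit and not a number. The value of compound 2, > 1000 nM, is also a limit.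

Compound 4 `CC1(C)O[C@@H](CO)[C@H](Cn2cc(Cn3c4c(c5ccccc53)C(=O)c3c[n+]([O-])c5ccccc5c3C4=O)nn2)O1` carries 5-(hydroxymethyl)-2,2-dimethyl-1,3-dioxolan-4-yl in place of the 1,2-dihydroxyethyl of compound 3, on a saturated chain carbon bound to an aromatic nitrogen (5-(hydroxymethyl)-2,2-dimethyl-1,3-dioxolan-4-yl in place of 1,2-dihydroxyethyl on a saturated chain carbon bound to an aromatic nitrogen). The closest guides are an at least 6.6-fold higher number from compound 1 to compound 2 (0.82 log units; beyond the scatter) and an at least 6.6-fold higher number from compound 1 to compound 3 (0.82 log units; beyond the scatter), both of which end in the open 2,3-dihydroxypropyl. Compound 1 has a different ring from compound 4, so these steps are only a loose guide, but they point towards a stronger inhibitor. The expected step is an at least 1.6-fold lower number from compound 3 to compound 4 (0.22 log units; that floor lies within the scatter), and it is uncertain. For compound 4 the estimated value is 600 nM, with an expected range from 150 nM to 2000 nM.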

Compound 4, half-maximal inhibitory concentration: > 1000 nM
Compound 4 was reported as a limit (the forecaster's own chance of this, stated with the estimate: 40%); middle value at least 1.6-fold (0.22 log units) away from the limit.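

In this assay compound 4 gives > 1000 nM, which is a limit. A ring in the side chain is therefore not enough by itself to match compound 1, as this new ring-bearing group still shows an at least 6.6-fold higher number from compound 1 to compound 4 (0.82 log units; beyond the scatter). The steps from compound 2 and compound 3 to compound 4 cannot be read because all three stop at the same limit: the limit of > 1000 nM in this assay, at which 3 of the 4 values shown sit.

On these data alone, how compound 2, compound 3 and compound 4 truly rank remains open. Also open, as far as these compounds go, is whether an amine or a carboxylic acid on this side chain would come closer to compound 1.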